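The source may report more compounds than this note shows. Statements on the series, on what has been measured and on what is new or still open speak of the compounds shown alone.

Of the compounds shown here, three built on one shared core have been tested in a functional assay on HT-29 cells (Homo sapiens) for inhibition, read by sulforhodamine B assay, with a stated time of 48 h, tested at 10 uM; on this read-out lower numbers stand for less inhibition and higher numbers for more inhibition at the one concentration tested (going by the name of the read-out). Compound 1 `COc1ccc(-c2cn3ccnc3c(-c3ccc4ncn(C5CCCCC5)c4c3)n2)cc1` gives 92.5%. Compound 2 `c1ccc2c(-c3cn4ccnc4c(-c4ccc5ncn(C6CCCCC6)c5c4)n3)cccc2c1` gives 4.11%, and compound 3 `c1csc(-c2cn3ccnc3c(-c3ccc4ncn(C5CCCCC5)c4c3)n2)c1` gives 0.09%. Among these three numbers compound 2 stands second highest: the step of a number 88.4 percentage points lower from compound 1 to compound 2 (beyond the scatter) lies beyond the scatter, whereas the step of a number 4 percentage points lower from compound 2 to compound 3 (within the scatter) lies within it, so compound 2 and compound 3 cannot be told apart on these readings. Compound 4 `c1ccc(Cn2cnc3ccc(-c4nc(-c5cccc6ccccc56)cn5ccnc45)cc32)cc1` differs from compound 2 in a single place: benzyl in place of cyclohexyl on an aromatic nitrogen. Going by the values given here, none of the measured steps touches this group; each of them, including a number 92.4 percentage points lower from compound 1 to compound 3 (beyond the scatter), swaps the group on an aromatic carbon instead. The measured steps therefore give no guide to the size or direction of the step to compound 4, and no change beyond the scatter is assumed. Compound 4 is expected to give 10% in this assay, within an estimated range from 0% to 40%. This estimate corresponds to an expected step of a number 5.9 percentage points higher from compound 2 to compound 4 (within the scatter).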

Compound 4, a percentage reported as inhibition, at one concentration (the size of the read-out at that concentration, not a potency): 18.6%
For compound 4 the middle estimate is 8.6 percentage points below the measured one; low and high end bracket the measured number.
By their numbers in this assay, from the lowest: compounds 3 and 2 (each within the scatter of the next); then compound 4; then compound 1.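

Benzyl in place of cyclohexyl on the aromatic nitrogen gives a number 14.5 percentage points higher from compound 2 to compound 4 (beyond the scatter) in this assay, which shows that the reading responds to this position as well as to the group on an aromatic carbon, the only place changed in the earlier steps. The change at the nitrogen is nevertheless smaller in size than the change on carbon, a number 88.4 percentage points lower from compound 1 to compound 2 (beyond the scatter). No measurement at hand explains why the number rises with benzyl.

From the compounds shown here alone, this step comes from one pair carrying naphthalen-1-yl, so it remains open whether the same swap would move the number similarly with 4-methoxyphenyl or thiophen-2-yl on the aromatic carbon. Also open, going by these compounds, is how a group such as an amine-bearing chain or a simple methyl on the aromatic nitrogen would read in this assay.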